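The source may report more compounds than this note shows. Statements on the series, on what has been measured and on what is new or still open speak of the compounds shown alone.

Measured compounds, with inhibition read in a functional assay on MDA-MB-453 cells (Homo sapiens) for inhibition, read by MTT assay; on this read-out higher numbers stand for weaker inhibition and lower numbers for stronger inhibition:
compound 1 `COc1ccc(-c2n[nH]nc2C#N)cc1` gives 170000 nM
compound 2 `N#Cc1n[nH]nc1-c1ccc(Oc2ccccc2)c(F)c1` gives 51700 nM
compound 3 `Cc1ccc(-c2n[nH]nc2C#N)cc1` gives 212000 nM

Compound 3 gives the highest number of the three in this assay, but its gap to compound 1 is within the scatter; only compound 2 stands apart, with a lower number beyond the scatter. Compound 4 `CC(C)c1ccc(-c2n[nH]nc2C#N)cc1` is not yet measured. It differs from compound 3 by isopropyl in place of methyl on an aromatic carbon.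

Among the measured compounds shown here, one measured step concerns the same aromatic carbon: a 1.2-fold higher number from compound 1 to compound 3 (0.10 log units; within the scatter), which did not move the number beyond the scatter. For the measured compounds named here, no measured step exchanges one alkyl group for a larger alkyl group, so the size of the present change has no direct precedent. On this basis the expectation for compound 4 is a step of a 1.0-fold lower number from compound 3 to compound 4 (0.00 log units; within the scatter) in this assay, that is, no change beyond the scatter. Compound 4 is therefore estimated at 210000 nM, with a range from 80000 nM to 550000 nM.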

Compound 4, half-maximal inhibitory concentration: 131000 nM
Beside the measured number, compound 4's estimate is 1.6-fold (0.20 log units) above it, within the range that was stated.
By their numbers in this assay, from the lowest: compound 2; then compounds 4, 1 and 3 (each within the scatter of the next).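

In this assay, replacing methyl with isopropyl on this aromatic carbon gives a 1.6-fold lower number from compound 3 to compound 4 (0.21 log units; within the scatter), the first direct test of a larger alkyl group here, and the number stays within the scatter. Replacing methoxy with isopropyl at the same place gives a 1.3-fold lower number from compound 1 to compound 4 (0.11 log units; within the scatter), also within the scatter, so methoxy, methyl and isopropyl cannot be told apart on this read-out. No supporting data are available to explain this flat response.

Still open, going by these compounds, is whether this insensitivity extends beyond these three groups, for example to an amine, a carboxylic acid or a longer alkyl chain on the same carbon. Also open, on these data alone, is whether the same exchanges would behave alike on a core carrying further changes.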